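The compounds below may be only part of what the source reports. "The series", "measured", "known", "first", "only" and "open" are said of these compounds alone.

Compound 1 `Cc1cnc(Nc2ccc(C(C)C)cc2)nc1Nc1nc2ccccc2s1` is the starting point of this account. In a functional assay on HeLa cells (Homo sapiens) for antiproliferative activity, read by MTT assay, with a stated time of 48 h (a lower number here means a stronger inhibitor, a higher number a weaker inhibitor), compound 1 gives > 50000 nM, which is a limit of the assay rather than a measured number. Two related compounds have been measured with numbers: compound 2 `CS(=O)(=O)c1ccc(Nc2nccc(Nc3nc4ccc(F)cc4s3)n2)cc1` gives 560 nM in this assay, and compound 3 `NS(=O)(=O)c1ccc(Nc2ncc(F)c(Nc3nc4ccc(Cl)cc4s3)n2)cc1` gives 8770 nM in this assay. The gap between compound 2 and compound 3 is large, but each of them carries a sulfonyl-type substituent on the outer aromatic ring, whereas compound 1 carries isopropyl there.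

Compound 4 `Cc1cnc(Nc2ccc(S(N)(=O)=O)cc2)nc1Nc1nc2ccccc2s1` differs from compound 1 in a single place: sulfamoyl in place of isopropyl on an aromatic carbon, in words, sulfamoyl in place of isopropyl on an aromatic carbon. Going by the values given here, no pair of measured compounds isolates this change, so its size cannot be read off directly. What the data show is that compound 1 sits at the limit of > 50000 nM in this assay, at which 1 of the 3 values shown sits, while compound 2 and compound 3, both with a sulfonyl substituent, return numbers. On that basis compound 4 is expected to be a stronger inhibitor than compound 1, with the step of an at least 10-fold lower number from compound 1 to compound 4 (1.00 log units; beyond the scatter) expected to lie well beyond the usual scatter. For compound 4 the estimate is 5000 nM, with a range from 800 nM to 30000 nM.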

Compound 4, half-maximal inhibitory concentration: 2800 nM
Compound 4: the middle estimate sits 1.8-fold (0.25 log units) above what was measured; the range from low to high includes it.
By their numbers in this assay, from the lowest: compound 2; then compound 4; then compound 3. At a limit, above all of these: compound 1.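

Going by these compounds alone, compound 4 gives the first view of a change at this position alone: on the core of compound 1, sulfamoyl in place of isopropyl, para to a large group, brings an at least 17-fold lower number from compound 1 to compound 4 (1.25 log units; beyond the scatter) in this assay. Compound 2 and compound 3 could not show this, as each differs from compound 1 in more than one place, so their numbers left open whether the outer substituent by itself could move the read-out off the limit. The size of this step is known from one side only, and its true extent stays unread since compound 1 stands at a limit and not at a number: the limit of > 50000 nM in this assay, at which 1 of the 4 values shown sits.

The compounds shown leave open whether a carboxylic acid or an amine in the same place on the core of compound 1 would behave as sulfamoyl does, or whether something specific to sulfamoyl is at work. They also leave open whether the same exchange of isopropyl for sulfamoyl would bring a step of similar size on any other core.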